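Methyl in place of phenyl in the series

This account rests on a few compounds, and the source may have more. Where it says the series, first, only, none or still open, it means among the compounds named here.

In an ADME assay on MT4 cells (Homo sapiens) for cytotoxicity, read by MTT assay (a higher number here means that more compound is tolerated, a lower number that less compound is tolerated), compound 3 `O=C1c2ccccc2C(Cc2ccccc2)C(=O)N1O` gives 95000 nM. Compound 2 `CC(C)C1C(=O)N(O)C(=O)c2ccccc21` gives 123000 nM. Compound 1 `CCCCC1C(=O)N(O)C(=O)c2ccccc21` gives 25400 nM. Compound 3 and compound 2 lie within the scatter of each other, while the gap from compound 3 to compound 1 lies beyond the scatter.

Compound 4 `CCC1C(=O)N(O)C(=O)c2ccccc21` follows from compound 3 by methyl in place of phenyl on a saturated chain carbon bound to a saturated ring carbon.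

Two modest measured steps bear on this: a 4.8-fold higher number from compound 1 to compound 2 (0.69 log units; beyond the scatter) and a 3.7-fold higher number from compound 1 to compound 3 (0.57 log units; beyond the scatter). They end within the scatter of each other, leaving only the butyl member apart. No step beyond the scatter is therefore expected.

The estimated change is a 1.1-fold higher number from compound 3 to compound 4 (0.02 log units; within the scatter). For compound 4 the expected value is 100000 nM, with an estimated range of 45000 nM to 180000 nM.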

Compound 4, half-maximal cytotoxic concentration: 250000 nM
Compound 4: middle estimate off by 2.5-fold (0.40 log units), on the low side; measured number outside the range, above it.
By their numbers in this assay, from the lowest: compound 1; then compounds 3 and 2 (each within the scatter of the next); then compound 4.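

In this assay, methyl in place of phenyl on a saturated chain carbon bound to a saturated ring carbon raises the number more than the neighbouring values suggested (a 2.6-fold higher number from compound 3 to compound 4 (0.42 log units; beyond the scatter)). The other two steps (a 2.0-fold higher number from compound 2 to compound 4 (0.31 log units; beyond the scatter)) and (a 9.8-fold higher number from compound 1 to compound 4 (0.99 log units; beyond the scatter)) also lie beyond the scatter, leaving compound 4 the highest of the four. Size alone does not order the series: compound 3, with its phenyl, stands within the scatter of compound 2 and above compound 1.

From the compounds shown here alone, whether an amine or a carboxylic acid at this place would keep the number this high remains open. Nothing shown accounts for the rise.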